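This account rests on a few compounds, and the source may have more. Where it says the series, first, only, none or still open, it means among the compounds named here.

Measured so far:
- Compound 1 `COc1cc(/C=C/C(=O)/C=C/c2cccc3ccccc23)ccc1OCc1cn(CCCCCOc2cc(=O)oc3ccccc23)nn1`: 40%
- Compound 2 `COc1cc(/C=C/C(=O)/C=C/c2ccccc2)ccc1OCc1cn(CCCCCOc2cc(=O)oc3ccccc23)nn1`: 22%

Both values come from a functional assay on COLO 205 cells (Homo sapiens) for inhibition, read by sulforhodamine B assay, with a stated time of 48 h, tested at 50 uM; a lower number here means less inhibition of growth, a higher number more inhibition of growth at the concentration tested. Of the two, compound 2 stands lower at 22%, and compound 1 lies above it, beyond the scatter.

The next analogue, compound 3 `COc1cc(/C=C/C(=O)/C=C/c2cc(OC)c(OC)c(OC)c2)ccc1OCc1cn(CCCCCOc2cc(=O)oc3ccccc23)nn1`, keeps the rest of compound 2 and changes one group: 3,4,5-trimethoxyphenyl in place of phenyl on a double-bonded chain carbon bound to a double-bonded chain carbon. The exchange takes place on a double-bonded chain carbon bound to a double-bonded chain carbon. Within the data shown here, the one measured step, a number 18 percentage points lower from compound 1 to compound 2 (beyond the scatter), changed the group at this same place, with phenyl replacing naphthalen-1-yl. It is modest but beyond the scatter, and it shows that this place can move the read-out. Among the measured compounds shown here, no measured compound carries methoxy groups on this ring, so the data give only a weak indication of direction. The expected change, a number 10 percentage points higher from compound 2 to compound 3 (within the scatter), is an estimated modest rise, no larger than the measured step, although a result within the scatter of compound 2 would not be surprising. Compound 3 is estimated at 32%, with an expected range from 15% to 52%.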

Compound 3, percent growth inhibition at one concentration: 51%
Beside the measured number, compound 3's estimate is 19 percentage points below it, and the stated range covers the measured number.
By their numbers in this assay, from the lowest: compound 2; then compound 1; then compound 3.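

In this assay, the change a number 29 percentage points higher from compound 2 to compound 3 (beyond the scatter) shows that this place on a double-bonded chain carbon bound to a double-bonded chain carbon can raise the read-out when the phenyl ring carries methoxy groups, so an unsubstituted phenyl is not the limit of what the place allows. The comparison a number 11 percentage points higher from compound 1 to compound 3 (beyond the scatter) adds that 3,4,5-trimethoxyphenyl also surpasses naphthalen-1-yl, which had been the better of the two groups seen earlier, and among these three compounds the group at this place alone sets the order, with phenyl lowest and 3,4,5-trimethoxyphenyl highest. Nothing in the available data explains why the trimethoxy-substituted ring gives the higher growth inhibition.

The compounds shown leave open whether all three methoxy groups are needed, or whether a single methoxy group on the phenyl ring would carry the same gain. They also leave open how an amine or a carboxylic acid on this ring would compare, and whether the same order would hold at any concentration other than the one tested.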